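Phenyl in Place of Hexyloxy: What to Expect

The source may hold more compounds than are shown below. What is called first, only, known or untested is meant among the compounds shown, and "the series" means these compounds.

Of the compounds shown here, three of one series have been measured in an assay (Cavia porcellus) for inhibition of Polyunsaturated fatty acid 5-lipoxygenase (Homo sapiens); a higher number here means a weaker inhibitor, a lower number a stronger inhibitor. Compound 1 `CN(O)C(=O)C1=Cc2ccccc2OC1` gives 830 nM in this assay. Compound 2 `CCCCCCOc1ccc2c(c1)C=C(CN(O)C(N)=O)CO2` gives 280 nM. Compound 3 `CCOC(=O)CNC(=O)N(O)CC1=Cc2cc(Oc3ccccc3)ccc2OC1` gives 68 nM. Among these three numbers compound 2 stands second highest: compound 1 lies a step above it that is beyond the scatter, and compound 3 lies further below it, again beyond the scatter. Among the compounds with values here, none of these pairs differs in a single place, so no clean step between measured compounds is available.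

Compound 4 `NC(=O)N(O)CC1=Cc2cc(-c3ccccc3)ccc2OC1` is not yet measured. It differs from compound 2 in one place: phenyl in place of hexyloxy on an aromatic carbon that is meta to a fused ring and para to a fused ring. Compound 3 carries phenoxy at that kind of position and gives the lowest number of the three, but it also carries a different group on the urea nitrogen, so its value cannot be read as the effect of the aromatic substituent alone.

Within the data shown here, with no matched step to lean on, the estimate for compound 4 is centred a little below compound 2, and the expected step from compound 2 to compound 4 is a 1.4-fold lower number from compound 2 to compound 4 (0.15 log units; within the scatter), which could well lie within the scatter. Compound 4 is expected to give about 200 nM in this assay, within a range from 60 nM to 700 nM.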

Compound 4, half-maximal inhibitory concentration: 240 nM
Compound 4: the middle estimate sits 1.2-fold (0.08 log units) below what was measured, and the stated range covers the measured number.
By their numbers in this assay, from the lowest: compound 3; then compounds 4 and 2 (each within the scatter of the next); then compound 1.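

In this assay, within the data shown here, the change at this position comes to a 1.2-fold lower number from compound 2 to compound 4 (0.07 log units; within the scatter), so the first clean reading of this aromatic carbon, meta to a fused ring and para to a fused ring, shows no difference that can be told from the scatter. The two groups are unlike in kind: hexyloxy is an open chain with no ring and one hydrogen-bond acceptor, whereas phenyl is one six-membered aromatic ring of carbon only with no hydrogen-bond acceptor, yet this single pair gives numbers that lie within the scatter of each other. No measurement shown here bears on why these two groups read alike.

This one pair cannot tell whether other groups at the same carbon, such as a carboxylic acid, an amine or a shorter chain like methoxy, would also read alike, so it sets no general rule for the position. No compound shown differs from compound 3 in one place, so the contribution of its phenoxy group remains unseparated from that of the group on its urea nitrogen.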